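Acylated diterpenes: from compound 3 to compound 4

This account rests on a few compounds, and the source may have more. Where it says the series, first, only, none or still open, it means among the compounds named here.

- compound 1 `C=C1[C@H](OCC(C)C)C2=C(C[C@@](C)(OC(C)=O)[C@@H]2OC(C)=O)[C@@H](OC(=O)c2ccccc2)[C@@H](C)/C=C/C(C)(C)[C@H](OC(C)=O)[C@H](OC(C)=O)[C@H]1OCC(C)C`: > 100000 nM (limit)
- compound 2 `C=C1[C@H](OC(=O)c2cccc(C)c2)[C@@H](O)[C@@H](O)C(C)(C)/C=C/[C@H](C)[C@H](OC(=O)c2ccccc2)[C@@]2(O)C[C@@](C)(O)[C@H](OC(C)=O)[C@@H]2[C@H]1OCC(C)C`: 33600 nM
- compound 3 `C=C1[C@H](OC(C)=O)[C@@H](OC(C)=O)[C@@H](OC(C)=O)C(C)(C)/C=C/[C@H](C)[C@H]2O[C@]3(C)C[C@@]2(OC(=O)c2ccccc2)[C@H]([C@H]3OC(C)=O)[C@H]1OCC(C)C`: > 100000 nM (limit)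

The read-out throughout is a functional assay on NCI/ADR-RES cells (Homo sapiens) for antiproliferative activity, read by MTT assay, with a stated time of 48 h; a lower number here means a stronger inhibitor, a higher number a weaker inhibitor. For the measured compounds named here, in this series, compound 2 gives 33600 nM, the only actual number among the three. Compound 1 gives > 100000 nM, which is a limit of the assay. Compound 3 gives > 100000 nM, also a limit and not a number. Compound 3 thus stands with compound 1 at the limit of > 100000 nM in this assay, at which 2 of the 3 values shown sit.

The next compound is compound 4 `C=C1[C@H](OC(C)=O)[C@@H](OC(=O)C(C)(C)C)[C@@H](OC(C)=O)C(C)(C)/C=C/[C@H](C)[C@H]2O[C@]3(C)C[C@@]2(OC(=O)c2ccccc2)[C@H]([C@H]3OC(C)=O)[C@H]1OCC(C)C`. It carries tert-butyl in place of methyl on a carbonyl carbon, turning one acetoxy into ((tert-butyl)carbonyl)oxy: tert-butyl in place of methyl on a carbonyl carbon. Going by the values given here, no measured pair shows a change of this kind, and the starting point is only a limit. No step beyond the usual scatter is expected in this assay, and another limit is the likeliest report. The expected step, a number no higher from compound 3 to compound 4 (the limit leaves the size open), is an estimate with no firm direction. The estimate for compound 4 is 100000 nM, within an expected range of 40000 nM to 200000 nM.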

Compound 4, half-maximal inhibitory concentration: > 100000 nM
Compound 4 ended at the assay's limit (the forecaster's own chance of this, stated with the estimate: 75%); the middle value sits exactly at the limit.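

Compound 3 and compound 4 both sit at the assay's limit, so no step can be read between them. What replacing methyl with tert-butyl on a carbonyl carbon does to activity remains open, with most of the series at that limit: the limit of > 100000 nM in this assay, at which 3 of the 4 values shown sit.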